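The source may hold more compounds than are shown below. What is called first, only, known or untested is meant among the compounds shown, and "the series" means these compounds.

Three compounds of one series have been run in an ADME assay for metabolic stability, read by HPLC, at pH 7.4 (on this read-out lower numbers stand for a shorter-lived compound and higher numbers for a longer-lived compound), so far. Compound 1, `CCCCCCCCNC(=O)Oc1ccc(Cl)cc1C(=O)Nc1ccc(Cl)cc1`, gives 43 h in this assay. Compound 2, `CCCCCCCCCNC(=O)Oc1ccc(Cl)cc1C(=O)Nc1ccc(Cl)cc1`, gives 43 h in this assay. Compound 3, `CCCCCNC(=O)Oc1ccc(Cl)cc1C(=O)Nc1ccc(Cl)c(Cl)c1`, gives 43 h in this assay, a value level with those of compounds 1 and 2 within the scatter. The change from compound 1 to compound 2 is methyl in place of hydrogen on a saturated chain carbon, eight bonds along the chain from an amide-type nitrogen, and the step it made in this assay is no change at the digits printed from compound 1 to compound 2 (within the scatter). Compound 3 rests on a core that differs from that of compound 1, and the difference between the two cores is not broken down here.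

Compound 4, `CCCCCCNC(=O)Oc1ccc(Cl)cc1C(=O)Nc1ccc(Cl)c(Cl)c1`, has not yet been measured in this assay. It differs from compound 3 by methyl in place of hydrogen on a saturated chain carbon, five bonds along the chain from an amide-type nitrogen, the same kind of change as that from compound 1 to compound 2, though the place is not the same: in the earlier pair the added methyl sits eight bonds along the chain from the amide-type nitrogen, whereas here it sits five bonds along. Because the earlier step of no change at the digits printed from compound 1 to compound 2 (within the scatter) left the half-life unchanged within the scatter, the corresponding step on the core of compound 3 is expected to be no change at the digits printed from compound 3 to compound 4 (within the scatter). On that basis compound 4 is estimated to show 43 h in this assay, with an expected range from 24 h to 78 h.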

Compound 4, half-life: 43 h
The estimate for compound 4 equals the measured number at the digits printed; the range from low to high includes it.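

In this assay, the step on the core of compound 3 reads no change at the digits printed from compound 3 to compound 4 (within the scatter), and set beside the earlier step on the core of compound 1, the same change gives the same result on both cores: the same change on two cores in this assay, no change at the digits printed (within the scatter) from compound 1 to compound 2 and no change at the digits printed (within the scatter) from compound 3 to compound 4, 1.0-fold (0.00 log units) apart, within the scatter of two such steps. Within these two pairs, then, the added methyl passes from one core to the other with no visible shift in half-life, even though it sits eight bonds along the chain from the amide-type nitrogen in one pair and five bonds along in the other. This does not show that a real effect of the change carries between cores, for neither step moves the half-life beyond the scatter, and two flat steps say nothing about other places on the chain or about cores beyond these two.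

The compounds shown leave open how the half-life would respond to a branched chain, or to a chain ending in an amine or a carboxylic acid rather than in plain methyl. They also leave open what would follow if a urea took the place of the carbamate, or if fluorine took the place of the chlorines.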